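A Carbamoyl Swap at the Assay Limit

The compounds below may be only part of what the source reports. "The series", "measured", "known", "first", "only" and "open" are said of these compounds alone.

Of the compounds shown here, three sharing one core have been tested in an ADME assay on Raji cells (Homo sapiens) for cytotoxicity, with a stated time of 72 h (on this read-out higher numbers stand for an effect only at larger amounts of compound and lower numbers for an effect already at smaller amounts), and only one gives a true number. Compound 1 (`Cc1cc(NC(=O)Nc2ccc(Cl)c(Cl)c2)c2ccccc2n1`) reads 10000 nM in that test. Compound 2 (`CSc1ccc(NC(=O)Nc2cc(C)nc3ccccc23)cc1`) reads > 25000 nM which is a limit of the assay and not a number. Compound 3 (`Cc1cc(NC(=O)Nc2cccc([N+](=O)[O-])c2)c2ccccc2n1`) reads > 25000 nM which is also a limit and not a number. On these data alone, compound 3 therefore stands at the limit of > 25000 nM in this assay, at which 2 of the 3 values shown sit, and its true value remains unknown.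

Compound 4 (`Cc1cc(NC(=O)Nc2cccc(C(N)=O)c2)c2ccccc2n1`) has not yet been measured. It carries carbamoyl in place of nitro on an aromatic carbon, meta to a large group (carbamoyl in place of nitro on an aromatic carbon). Among the compounds with values here, no two measured compounds differ in only one place, so no measured step shows how large such a change can be. The expectation leans on compound 3 with its limit of > 25000 nM as the closest neighbour. In this assay no step beyond the usual scatter is expected in either direction, and the estimated a number no higher from compound 3 to compound 4 (the limit leaves the size open) should be read in that sense. For compound 4 the estimate is 25000 nM with an expected range from 10000 nM to 50000 nM and a good chance of only a limit.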

Compound 4, half-maximal effective concentration: > 25000 nM
Compound 4 gave a limit, no number; the forecaster's own chance of this, stated with the estimate: 75%; the middle value sits exactly at the limit.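

No step can be read from compound 3 to compound 4 in this assay, because both compounds give a limit and not a number: the limit of > 25000 nM in this assay, at which 3 of the 4 values shown sit.

The compounds shown leave open how far carbamoyl in place of nitro on an aromatic carbon shifts this read-out, and where the true values of compound 2, compound 3 and compound 4 lie.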